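The source may hold more compounds than are shown below. What is called first, only, known or untested is meant among the compounds shown, and "the series" means these compounds.

Measured compounds:
compound 1, `Cc1ccc2cccc(NS(=O)(=O)c3ccccc3[N+](=O)[O-])c2n1`, 6800 nM
compound 2, `Cc1ccc2cccc(NS(=O)(=O)c3ccc(C(F)(F)F)cc3[N+](=O)[O-])c2n1`, 10000 nM
compound 3, `COc1ccc(S(=O)(=O)Nc2cccc3ccc(C)nc23)c([N+](=O)[O-])c1`, "not determined" (no result reported)

In an assay on OCI-Ly3 cells for activation of NF-kappa-B inhibitor alpha (Homo sapiens), read by a luciferase reporter (on this read-out lower numbers stand for an effect already at smaller amounts and higher numbers for an effect only at larger amounts of compound), compound 1 gives the lowest of the two numbers, and compound 2 sits within the scatter of it: a 1.5-fold higher number from compound 1 to compound 2 (0.17 log units; within the scatter). For compound 3 no result is reported.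

Compound 4, `Cc1ccc2cccc(NS(=O)(=O)c3ccccc3N)c2n1`, differs from compound 1 as follows: amino in place of nitro on an aromatic carbon. None of the measured steps bears on this change; the only step shown concerns trifluoromethyl in place of hydrogen. Without a comparable step, nothing beyond the scatter is expected in this assay, but the range is wide. Compound 4 is estimated at 9000 nM (range 3000 nM to 30000 nM), a step of a 1.3-fold higher number from compound 1 to compound 4 (0.12 log units; within the scatter) that is expected rather than known.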

Compound 4, half-maximal effective concentration: 8000 nM
Compound 4: middle estimate off by 1.1-fold (0.05 log units), on the high side; the measured number falls inside the stated range.
By their numbers in this assay, from the lowest: compounds 1, 4 and 2 (each within the scatter of the next).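

In this assay, amino in place of nitro on the aromatic carbon ortho to a large group gives a 1.2-fold higher number from compound 1 to compound 4 (0.07 log units; within the scatter), so this exchange stays within the scatter. Going by these compounds alone, compound 4 is the first compound here with a measured number that carries no nitro, showing that a number in this range does not depend on nitro in this one pair. No available evidence accounts for the result. Open, going by these compounds, is whether a carboxylic acid or an acetamide on this carbon would give a step beyond the scatter, and whether the amino exchange would behave alike alongside trifluoromethyl.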